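The source may report more compounds than this note shows. Statements on the series, on what has been measured and on what is new or still open speak of the compounds shown alone.

Measured compounds in a functional assay on ECa-109 cells for inhibition, with ECa-109 cell line (Homo sapiens) as the target, read by sulforhodamine B assay; a lower number here means a stronger inhibitor, a higher number a weaker inhibitor:
- compound 1, `O=C1C(N2CCCCC2)=CC(=O)c2c1nc1n2[C@H]2OC[C@@H](O)[C@H]2OC1`: compound 1 gives > 8000 nM, a limit of the assay and not a number.
- compound 2, `COc1cccc(NC2=CC(=O)c3c(nc4n3[C@H]3OC[C@@H](O)[C@H]3OC4)C2=O)c1`: compound 2 gives 3340 nM.
- compound 3, `O=C1C=C(N2CCCCC2)C(=O)c2c1nc1n2[C@H]2OC[C@@H](O)[C@H]2OC1`: compound 3 gives > 8000 nM, again a limit and not a number.

Compound 1 and compound 3 share the same atoms joined differently; the difference between the two cores is not broken down here. Within the data shown here, the one measured step is an at least 2.3-fold lower number from compound 1 to compound 2 (0.37 log units; beyond the scatter), the change being ((3-methoxyphenyl)amino in place of piperidin-1-yl on a double-bonded ring carbon). Its size is known only as a lower bound because of the limit of > 8000 nM in this assay, at which 2 of the 3 values shown sit.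

Not yet measured is compound 4, `COc1cccc(NC2=CC(=O)c3nc4n(c3C2=O)[C@H]2OC[C@@H](O)[C@H]2OC4)c1`. It carries the same change on the core of compound 3, ((3-methoxyphenyl)amino in place of piperidin-1-yl on a double-bonded ring carbon), with the place described in the same words, so it is the same change as that from compound 1 to compound 2. Among the measured compounds shown here, with compound 3 at a limit, the expected step is an at least 1.6-fold lower number from compound 3 to compound 4 (0.20 log units; that floor lies within the scatter), resting on an at least 2.3-fold lower number from compound 1 to compound 2 (0.37 log units; beyond the scatter) as the only guide, with no measured anchor for the core of compound 3. Compound 4 is therefore expected near 5000 nM, within 1500 nM to 15000 nM.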

Compound 4, half-maximal inhibitory concentration: 7620 nM
Compound 4: the middle estimate sits 1.5-fold (0.18 log units) below what was measured; the range from low to high includes it.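

In this assay, (3-methoxyphenyl)amino in place of piperidin-1-yl on the second core gives an at least 1.0-fold lower number from compound 3 to compound 4 (0.02 log units; that floor lies within the scatter), so the only firm statement for this core is a floor that does not clear the scatter. This floor is not a size, and the data show neither that the change carries over with the same size nor that it loses size on moving between the cores: the same change on two cores in this assay, an at least 2.3-fold lower number (0.37 log units; beyond the scatter) from compound 1 to compound 2 and an at least 1.0-fold lower number (0.02 log units; that floor lies within the scatter) from compound 3 to compound 4; the limit leaves it open whether they differ Both steps start from a limit and not a number, which keeps any reading of transfer open: the limit of > 8000 nM in this assay, at which 2 of the 4 values shown sit.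

On these data alone, the true size of the step on either core stays unknown while the piperidin-1-yl compounds are known only as limits. Also open, as far as these compounds go, is whether the pattern holds for other amino groups on both cores, such as phenylamino without the methoxy group or morpholin-4-yl, which would show whether the aromatic ring or the methoxy group goes with the lower number on the core of compound 1.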